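Removal of the chloro substituent from compound 1

A few compounds are considered here, and "the series" means these few. Any claim that something is new, unique, unknown or untested is made for them only; others in the source may bear on it.

Measured compounds:
- compound 1, `O=c1c(C2N=C(c3ccccc3)SS2)coc2ccc(Cl)cc12`: 73%
- compound 2, `O=c1c(C(=S)Nc2ccccc2)coc2cc(Cl)c(Cl)cc12`: 3%

In a functional assay on A549 cells (Homo sapiens) for inhibition, read by sulforhodamine B assay, with a stated time of 48 h, tested at 100 uM (a lower number here means less inhibition of growth, a higher number more inhibition of growth at the concentration tested), compound 1 gives 73%, the highest of the two numbers. For the measured compounds named here, compound 2 gives 3% in this assay, a gap beyond the scatter, but the two structures differ in several places at once and no single step connects them.

Compound 3, `O=c1c(C2N=C(c3ccccc3)SS2)coc2ccccc12`, has not yet been measured. Relative to compound 1 the change is hydrogen in place of chloro on an aromatic carbon; hydrogen in place of chloro on an aromatic carbon, meta to a fused ring and para to a fused ring of the shared core. Going by the values given here, no step of this kind has been measured, so its size is open. A modest decrease is expected, possibly no larger than the scatter, and the step from compound 1 to compound 3 is estimated at a number 15 percentage points lower from compound 1 to compound 3 (beyond the scatter). Compound 3 is accordingly expected to give about 58% in this assay, within a range of 35% to 78%.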

Compound 3, percent growth inhibition at one concentration: 42%
Estimate against measurement, compound 3: 16 percentage points above; measured number inside the range.
By their numbers in this assay, from the lowest: compound 2; then compound 3; then compound 1.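

In this assay, for the compounds shown here, hydrogen in place of chloro on the aromatic carbon, meta to a fused ring and para to a fused ring, gives a number 31 percentage points lower from compound 1 to compound 3 (beyond the scatter) as the first single-place step, so this position is sensitive to this change. Removal of the chloro does not abolish the effect, since compound 3 still gives 42% in this assay at the concentration tested. Nothing available bears on what lies behind the size of this step.

From the compounds shown here alone, whether fluoro, bromo or methoxy at this place would match or exceed compound 1 remains open. Also open, going by these compounds, is whether chloro on another aromatic carbon of the shared core would give a step of similar size.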